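Replacing the ring urea with a direct phenyl link

The compounds below may be only part of what the source reports. "The series", "measured", "known", "first", "only" and "open" are said of these compounds alone.

Measured so far:
compound 1 `O=C(/C(=N/O)Nc1ccc(F)c(Br)c1)C1CCN(C(=O)Nc2ccccc2)CC1` 40 nM
compound 2 `Cn1cc(-c2ccc(NC(=O)N3CCC(C(=O)/C(=N/O)Nc4ccc(F)c(Br)c4)CC3)cc2)cn1` 14 nM

In an assay for inhibition of Indoleamine 2,3-dioxygenase 1 (Homo sapiens), with a stated time of 1 h (on this read-out lower numbers stand for stronger inhibition and higher numbers for weaker inhibition), compound 1 gives 40 nM, the higher of the two numbers recorded. Compound 2 gives 14 nM. Among the compounds with values here, the single measured step is a 2.9-fold lower number from compound 1 to compound 2 (0.46 log units; beyond the scatter), a change at the outer aromatic ring only.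

Compound 3 `O=C(/C(=N/O)Nc1ccc(F)c(Br)c1)C1CCN(c2ccccc2)CC1` differs from compound 1 by phenyl in place of phenylcarbamoyl on an amine nitrogen in a ring. Within the data shown here, the step from compound 1 to compound 2 touches a different part of the molecule and does not bear on this position; no measured pair speaks to the change at the ring nitrogen. The group that leaves carries one hydrogen-bond donor and one acceptor, the entering phenyl none, and the entering group is also smaller. Among the measured compounds shown here, a weaker number is expected for compound 3, of modest size and uncertain, because the only anchor is compound 1 itself with 40 nM in this assay. Compound 3 is estimated at 150 nM with a range of 40 nM to 600 nM. The expected step is therefore a 3.8-fold higher number from compound 1 to compound 3 (0.57 log units; beyond the scatter).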

Compound 3, half-maximal inhibitory concentration: 149 nM
Compound 3: the middle estimate sits 1.0-fold (0.00 log units) above what was measured, within the range that was stated.
By their numbers in this assay, from the lowest: compound 2; then compound 1; then compound 3.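

Putting phenyl in place of phenylcarbamoyl on the amine nitrogen in the ring gives a 3.7-fold higher number from compound 1 to compound 3 (0.57 log units; beyond the scatter) in this assay, so this position, which the earlier step did not touch, does respond to substitution. The step is modest, and compound 3 still gives 149 nM, so the carbonyl and the amide hydrogen of the phenylcarbamoyl group are not indispensable for a number in this range. No available evidence bears on the origin of this step.

Going by these compounds, it remains open whether a benzyl or benzoyl group on the same ring nitrogen would give a number nearer that of compound 1 or that of compound 3. Also open, on these data alone, is whether 1-methyl-1H-pyrazol-4-yl, which gave a 2.9-fold lower number from compound 1 to compound 2 (0.46 log units; beyond the scatter), would give a similar step on the phenyl of compound 3.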